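Tellurium-to-selenium swap on the long-chain sulfate series

A few compounds are considered here, and "the series" means these few. Any claim that something is new, unique, unknown or untested is made for them only; others in the source may bear on it.

Compound 3 `O=S(=O)(O)OCCCCCCCCCCCC[Te]c1ccccc1` gives 19800 nM in a functional assay on HCT-116 cells (Homo sapiens) for cytotoxicity, read by MTT assay, with a stated time of 24 h (on this read-out lower numbers stand for stronger inhibition and higher numbers for weaker inhibition), the highest of the two numbers in this set. Compound 1 `O=S(=O)(O)OCCCCCCCCCC[Te]c1ccccc1` gives 7470 nM; the step from a 2.7-fold higher number from compound 1 to compound 3 (0.42 log units; beyond the scatter) is the only measured one. Compound 2 `O=S(=O)(O)OCCCCCCCCC[Se]c1ccccc1` reaches only a limit of the assay, (the limit of > 100000 nM in this assay, at which 1 of the 3 values shown sits), so that no number stands for it. Compound 4 `O=S(=O)(O)OCCCCCCCCCCC[Se]c1ccccc1` is not yet measured; it differs from compound 3 by a group of 7 heavy atoms (6 carbon, 1 selenium; one six-membered aromatic ring of carbon only) in place of a group of 8 heavy atoms (7 carbon, 1 tellurium; one six-membered aromatic ring of carbon only), on a saturated chain carbon, ten or more bonds along the chain from an oxygen. Among the measured compounds shown here, no measured step bears directly on the exchange of tellurium for selenium; the chain-lengthening step from a 2.7-fold higher number from compound 1 to compound 3 (0.42 log units; beyond the scatter) gives a modest rise but concerns a different change. For the measured compounds named here, compound 2, the only selenium member, shows no number, only > 100000 nM as a limit. The step from a 4.0-fold higher number from compound 3 to compound 4 (0.61 log units; beyond the scatter) is therefore expected to be upward, likely beyond the scatter, with a real chance that compound 4 also reaches only the limit. For compound 4 the estimate is 80000 nM, in a range from 20000 nM to 300000 nM.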

Compound 4, half-maximal inhibitory concentration: > 100000 nM
Compound 4 ended at the assay's limit; the forecaster's own chance of this, stated with the estimate: 50%; middle value at least 1.2-fold (0.09 log units) away from the limit.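

In this assay, the exchange on a saturated chain carbon now has a measured step, an at least 5.0-fold higher number from compound 3 to compound 4 (0.70 log units; beyond the scatter), and its size is only a lower bound. Compound 4 gives only a limit of the assay, > 100000 nM. With compound 2, both selenium members shown now end this way and the step between them cannot be read, while the tellurium members, compound 1 and compound 3, give numbers: the limit of > 100000 nM in this assay, at which 2 of the 4 values shown sit.

From the compounds shown here alone, how far the selenium members lie past the limit stays open, as does how much of the step belongs to selenium and how much to the one carbon fewer in the entering group. Also open, going by these compounds, is whether a carboxylic acid in place of sulfooxy, or a longer chain, would bring a selenium member to a readable number.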